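The source may report more compounds than this note shows. Statements on the series, on what has been measured and on what is new or still open speak of the compounds shown alone.

Compound 1 `CC1(C)CCOc2ccc(NC(=O)Nc3ccc([N+](=O)[O-])cc3)cc21` gives 6700 nM in a functional assay on A2780 cells (Homo sapiens) for inhibition, with a stated time of 72 h; on this read-out higher numbers stand for weaker inhibition and lower numbers for stronger inhibition.
Compound 2 `CCC1(CC)CC(CC)(CC)c2cc(NC(=S)Nc3ccc([N+](=O)[O-])cc3)ccc2O1` gives 4600 nM in this assay.
Compound 3 `CC1(C)CCOc2ccc(NC(=O)Nc3ccc(OC(F)(F)F)cc3)cc21` gives 3500 nM in this assay.

Compound 3 carries the lowest of the three numbers, yet its gaps to compound 2 and to compound 1 both sit within the scatter, so the three cannot be told apart in this assay. Compound 4 `CC1(C)CCOc2ccc(NC(=O)Nc3ccc(C(F)(F)F)cc3)cc21` differs from compound 3 in one place: trifluoromethyl in place of trifluoromethoxy on an aromatic carbon. For the measured compounds named here, the only measured step that bears on a change at this position is a 1.9-fold lower number from compound 1 to compound 3 (0.28 log units; within the scatter), a step within the scatter. On that basis no step beyond the scatter is expected for no change at the digits printed from compound 3 to compound 4 (within the scatter) in this assay. Compound 4 is therefore estimated at 3500 nM, with a range from 1200 nM to 10000 nM.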

Compound 4, half-maximal inhibitory concentration: 5000 nM
Compound 4: the middle estimate sits 1.4-fold (0.15 log units) below what was measured; measured number inside the range.
By their numbers in this assay, from the lowest: compounds 3, 2, 4 and 1 (each within the scatter of the next).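

In this assay, trifluoromethyl at this position gives a 1.4-fold higher number from compound 3 to compound 4 (0.15 log units; within the scatter) against trifluoromethoxy and a 1.3-fold lower number from compound 1 to compound 4 (0.13 log units; within the scatter) against nitro. With nitro, trifluoromethoxy and trifluoromethyl all within the scatter of one another on the shared core, this read-out does not separate the three groups on this aromatic carbon. Nothing measured here offers an explanation for this.

The compounds shown leave open whether an amine, a carboxylic acid or a hydroxyl group at this position would move the number beyond the scatter.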